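A Cyanopyridine in Place of Phenyl on the Piperidine

The compounds below may be only part of what the source reports. "The series", "measured", "known", "first", "only" and "open" are said of these compounds alone.

In a functional assay on HEK293 cells for agonist activity at D(4) dopamine receptor (Homo sapiens), read by FLIPR (a lower number here means that less compound is needed, a higher number that more compound is needed for the effect), compound 1 `Cc1cccc(NC(=O)CN2CCC(c3ccccc3)CC2)c1` gives 170 nM. Two related compounds, built on a different amide linkage and carrying a pyridine N-oxide on the saturated ring, were measured alongside it: compound 2 `O=C(NCN1CCC(c2cccc[n+]2[O-])CC1)c1ccc2ccccc2c1` gives 115 nM in this assay, and compound 3 `Cc1cc(C)cc(C(=O)NCN2CCC(c3cccc[n+]3[O-])CC2)c1` gives 90 nM. Both of these numbers lie within the usual scatter of the number for compound 1, so no ordering among the three can be claimed. Compound 4 `Cc1cccc(NC(=O)CN2CCC(c3cccc(C#N)n3)CC2)c1` differs from compound 1 in one place: 6-cyanopyridin-2-yl in place of phenyl on a saturated ring carbon. Among the compounds with values here, no measured pair shows this change, so the direction of the step is uncertain; a shift not far beyond the scatter is expected, and the step from compound 1 to compound 4 is estimated at a 1.4-fold lower number from compound 1 to compound 4 (0.15 log units; within the scatter). Compound 4 is therefore expected to give about 120 nM in this assay, with a range from 40 nM to 400 nM.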

Compound 4, half-maximal effective concentration: 36 nM
For compound 4 the middle estimate is 3.3-fold (0.52 log units) above the measured one; measured number below the stated range.
By their numbers in this assay, from the lowest: compound 4; then compounds 3, 2 and 1 (each within the scatter of the next).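

On the saturated ring carbon three ring bonds from the ring nitrogen, 6-cyanopyridin-2-yl in place of phenyl gives a 4.7-fold lower number from compound 1 to compound 4 (0.67 log units; beyond the scatter) in this assay and so shows that the number responds to the group at this position. The earlier compounds shown here offered no comparison in one place, and their numbers all lay within the scatter of one another. Nothing at hand gives a cause for this step. Going by these compounds, it remains open whether the ring nitrogen, the nitrile or both carry the step, which a plain pyridin-2-yl or a cyanophenyl group at this position would separate.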